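The source may report more compounds than this note shows. Statements on the series, on what has been measured and on what is new or still open speak of the compounds shown alone.

Measured compounds:
Compound 1 `Cc1ccc(N2CCN(C(=O)C3CCN(C(=O)c4ccc(S(C)(=O)=O)c([N+](=O)[O-])c4)CC3)CC2)cc1`: > 60000 nM
Compound 2 `CN1CCN(C(=O)CNC(=O)c2ccc(S(C)(=O)=O)c([N+](=O)[O-])c2)CC1`: > 60000 nM
Compound 3 `CS(=O)(=O)c1ccc(C(=O)NCCC(=O)N2CCc3ccccc32)cc1[N+](=O)[O-]`: > 60000 nM

In an assay on isolated protein for inhibition of vitamin D3 receptor (Homo sapiens), read by fluorescence polarization (on this read-out higher numbers stand for weaker inhibition and lower numbers for stronger inhibition), compound 1 gives > 60000 nM, which is a limit of the assay and not a number. Compound 2 gives > 60000 nM, again a limit. Compound 3 gives > 60000 nM, also a limit. So compound 2 stands nowhere distinct: every value here sits at the same boundary, (the limit of > 60000 nM in this assay, at which 3 of the 3 values shown sit), and no inhibition has been quantified for any of the three.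

Compound 4 `CC(C)N(C(=O)CNC(=O)c1ccc(S(C)(=O)=O)c([N+](=O)[O-])c1)C(C)C` differs from compound 2 in one place: diisopropylamino in place of 4-methylpiperazin-1-yl on a carbonyl carbon. Among the measured compounds shown here, no measured step between two compounds exists to guide the expectation, so in this assay no step beyond the scatter is expected in either direction. Compound 4 is therefore estimated at 100000 nM, with a range from 40000 nM to 300000 nM, most probably reported again only as a limit. The expected step is a step that the limit leaves unreadable from compound 2 to compound 4, within the scatter.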

Compound 4, half-maximal inhibitory concentration: > 60000 nM
Compound 4 ended at the assay's limit; the forecaster's own chance of this, stated with the estimate: 85%; the middle value does not contradict the limit.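

Among the compounds shown here, compound 2 and compound 4 both sit at the limit of the assay, so no step between them can be read. The compounds shown leave open which structure, if any, gives a measurable value in this assay.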